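A few compounds are considered here, and "the series" means these few. Any claim that something is new, unique, unknown or untested is made for them only; others in the source may bear on it.

Working notes on the series. Among the compounds with values here, in a functional assay on A549 cells (Homo sapiens) for inhibition, read by CCK-8 assay, with a stated time of 72 h, tested at 10 uM (on this read-out lower numbers stand for less inhibition of growth and higher numbers for more inhibition of growth at the one concentration tested), compound 2 `COc1cccc(NC(=O)C2(C(=O)Nc3ccc(Nc4ncc5cc(C(=O)N(C)C)n(C6CCCC6)c5n4)cc3)CC2)c1` gives 96%, the higher of the two numbers so far, and compound 1 `COc1ccc(NC(=O)C2(C(=O)Nc3ccc(Nc4ncc5cc(C(=O)N(C)C)n(C6CCCC6)c5n4)cc3)CC2)cc1` gives 78.5%. Compound 3 `CN(C)C(=O)c1cc2cnc(Nc3ccc(NC(=O)C4(C(=O)Nc5ccc(C#N)cc5)CC4)cc3)nc2n1C1CCCC1` is next, with this change: 4-cyanophenyl in place of 3-methoxyphenyl on an amide-type nitrogen. Within the data shown here, only one measured step bears on it, a number 17.5 percentage points higher from compound 1 to compound 2 (beyond the scatter), which is modest and beyond the scatter and swaps 4-methoxyphenyl for 3-methoxyphenyl at the same amide-type nitrogen. Among the measured compounds shown here, no measured compound carries 4-cyanophenyl, so a modest fall in this assay is expected only tentatively. The expected change is a number 16 percentage points lower from compound 2 to compound 3 (beyond the scatter). For compound 3 the estimate is 80%, with an expected range of 62% to 96%.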

Compound 3, percent growth inhibition at one concentration: 95%
Compound 3: the middle estimate sits 15 percentage points below what was measured; the range from low to high includes it.
By their numbers in this assay, from the lowest: compound 1; then compounds 3 and 2 (each within the scatter of the next).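

In this assay the step of a number 1 percentage points lower from compound 2 to compound 3 (within the scatter) places 4-cyanophenyl within the scatter of 3-methoxyphenyl on this amide-type nitrogen, so a group other than methoxy can read alike here. The step of a number 16.5 percentage points higher from compound 1 to compound 3 (beyond the scatter) shows that two 4-substituted phenyl groups at this nitrogen need not read alike. Nothing available explains either step. Still open, on these data alone, is how 3-cyanophenyl, unsubstituted phenyl or a phenyl carrying an amine or a carboxylic acid would read on this nitrogen.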